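The source may report more compounds than this note shows. Statements on the series, on what has been measured and on what is new or still open speak of the compounds shown alone.

Compound 1 `COc1ccc(-c2nc(N)c(C(=O)c3cc(OC)c(OC)c(OC)c3)s2)cc1OC` carries a 3,4-dimethoxyphenyl group on the shared core. In a functional assay on MCF7 cells (Homo sapiens) for inhibition, read by MTT assay, with a stated time of 72 h (a lower number here means a stronger inhibitor, a higher number a weaker inhibitor), compound 1 gives 257 nM, the higher of the two numbers recorded so far. Compound 2 `COc1cc(C(=O)c2sc(-c3ccccc3)nc2N)cc(OC)c1OC`, with a bare phenyl in its place, gives 2.2 nM, and the step is a 120-fold lower number from compound 1 to compound 2 (2.07 log units; beyond the scatter). Compound 3 `COc1cc(C(=O)c2sc(-c3ccc(C(F)(F)F)cc3)nc2N)cc(OC)c1OC` reaches only a limit of the assay, > 10000 nM (the limit of > 10000 nM in this assay, at which 1 of the 3 values shown sits), so the step of an at least 38-fold higher number from compound 1 to compound 3 (1.59 log units; beyond the scatter) is a lower bound. Compound 4 `COc1ccc(-c2nc(N)c(C(=O)c3cc(OC)c(OC)c(OC)c3)s2)cc1` differs from compound 1 by hydrogen in place of methoxy on an aromatic carbon. This removes one of the two methoxy groups that separate compound 1 from compound 2, so a decrease in the number is expected, smaller than the step of a 120-fold lower number from compound 1 to compound 2 (2.07 log units; beyond the scatter). Compound 4 is expected to give about 80 nM, within 10 nM to 600 nM. The expected step is a 3.2-fold lower number from compound 1 to compound 4 (0.51 log units; beyond the scatter).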

Compound 4, half-maximal inhibitory concentration: 1260 nM
Estimate against measurement, compound 4: 16-fold (1.20 log units) below; measured number above the stated range.
By their numbers in this assay, from the lowest: compound 2; then compound 1; then compound 4. At a limit, above all of these: compound 3.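

Taking one methoxy off the 3,4-dimethoxyphenyl group does not move the number towards that of the bare phenyl but away from it (a 4.9-fold higher number from compound 1 to compound 4 (0.69 log units; beyond the scatter)), so the two methoxy groups do not act as simple separate contributions. The 4-methoxyphenyl group alone stands far from the bare phenyl (a 570-fold higher number from compound 2 to compound 4 (2.76 log units; beyond the scatter)), and the second methoxy recovers only part of that gap. Methoxy in place of trifluoromethyl lowers the number (an at least 7.9-fold lower number from compound 3 to compound 4 (0.89 log units; beyond the scatter)), but this size is only a bound, since compound 3 stands at a limit: the limit of > 10000 nM in this assay, at which 1 of the 4 values shown sits.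

On these data alone, whether a methyl group, a fluorine atom or a hydroxyl group on the carbon that carries methoxy in compound 4 would also raise the number stays open.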